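Pyrrolidinyl for dimethylamino: cytotoxicity notes on a bicyclic series

The source may hold more compounds than are shown below. What is called first, only, known or untested is meant among the compounds shown, and "the series" means these compounds.

Compound 1 `CN(C)C12CC(=O)C(C(c3ccccc3)C1)C(c1ccccc1)C2` and compound 2 `O=C1CC2(N3CCCC3)CC(c3ccccc3)C1C(c1ccccc1)C2` share a core and differ by pyrrolidin-1-yl in place of dimethylamino on a saturated ring carbon. In an ADME assay on L6 cells (Rattus norvegicus) for cytotoxicity (a lower number here means a stronger inhibitor, a higher number a weaker inhibitor), compound 1 gives 24600 nM and compound 2 gives 26500 nM, so the change made a 1.1-fold higher number from compound 1 to compound 2 (0.03 log units; within the scatter). Compound 3 `COc1ccc(C2CC3(N(C)C)CC(=O)C2C(c2ccc(OC)cc2)C3)cc1` gives 52400 nM in this assay, a higher number than compound 1; the difference between the two cores is not broken down here. Compound 4 `COc1ccc(C2CC3(N4CCCC4)CC(=O)C2C(c2ccc(OC)cc2)C3)cc1` differs from compound 3 by pyrrolidin-1-yl in place of dimethylamino on a saturated ring carbon, the same kind of change as in the first pair, the place differing only in that the ring atom two ring bonds away bears a 4-methoxyphenyl group rather than a phenyl group. The step from compound 3 to compound 4 is expected to be a 1.1-fold higher number from compound 3 to compound 4 (0.04 log units; within the scatter), because the same kind of change earlier gave a 1.1-fold higher number from compound 1 to compound 2 (0.03 log units; within the scatter). Compound 4 is estimated at 57000 nM, expected between 28000 nM and 115000 nM.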

Compound 4, half-maximal inhibitory concentration: 41900 nM
The estimate for compound 4 lay 1.4-fold (0.13 log units) above the measured number; the measured number falls inside the stated range.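

In this assay, pyrrolidin-1-yl in place of dimethylamino on the core bearing 4-methoxyphenyl groups gives a 1.3-fold lower number from compound 3 to compound 4 (0.10 log units; within the scatter). The change therefore carries between these two cores without a detectable dependence on the core: the same change on two cores in this assay, a 1.1-fold higher number (0.03 log units; within the scatter) from compound 1 to compound 2 and a 1.3-fold lower number (0.10 log units; within the scatter) from compound 3 to compound 4, 1.3-fold (0.13 log units) apart, within the scatter of two such steps. Among these compounds, this rests on two pairs in a single assay, and since neither step leaves the scatter, it shows only that the swap is tolerated on both cores, not that it would stay as small on any other core.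

Still open, as far as these compounds go, is whether other cyclic amines on the same saturated ring carbon, such as piperidin-1-yl or morpholin-4-yl, behave alike. Also open, from the compounds shown here alone, is whether the step stays this small with aryl groups such as 4-chlorophenyl in place of phenyl or 4-methoxyphenyl.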